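The source may hold more compounds than are shown below. What is called first, only, known or untested is meant among the compounds shown, and "the series" means these compounds.

Measured so far:
compound 1, `Cc1cc(NC(=O)Nc2ccc(C(C)(C)C)cc2)c2ccccc2n1`: 20000 nM
compound 2, `Cc1cc(NC(=O)Nc2ccccc2N)c2ccccc2n1`: > 25000 nM
compound 3, `Cc1cc(NC(=O)Nc2cccc(C(N)=O)c2)c2ccccc2n1`: > 25000 nM

Three compounds sharing one core were tested in an ADME assay on BJ cells (Homo sapiens) for cytotoxicity, with a stated time of 72 h; on this read-out lower numbers stand for an effect already at smaller amounts and higher numbers for an effect only at larger amounts of compound. Compound 1, `Cc1cc(NC(=O)Nc2ccc(C(C)(C)C)cc2)c2ccccc2n1`, gives 20000 nM. For compound 2, `Cc1cc(NC(=O)Nc2ccccc2N)c2ccccc2n1`, the assay reports only a limit, > 25000 nM. For compound 3, `Cc1cc(NC(=O)Nc2cccc(C(N)=O)c2)c2ccccc2n1`, the result is likewise a limit, > 25000 nM. Compound 2 therefore stands at the limit of > 25000 nM in this assay, at which 2 of the 3 values shown sit; it has no number of its own, and compound 1 is the only one of the three with a value inside the measured range. No pair of these compounds differs in a single place, so no measured step is available to lean on.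

The next compound, compound 4, `Cc1cc(NC(=O)Nc2ccccc2F)c2ccccc2n1`, differs from compound 2 by fluoro in place of amino on an aromatic carbon. With compound 2 known only as a limit, this change cannot be read against any measured change of the same kind, and nothing among the three tested compounds points to a stronger effect in this assay. The step of a number no higher from compound 2 to compound 4 (the limit leaves the size open) is expected, that is, none beyond the scatter. For compound 4 an effective concentration of 25000 nM is expected, with a range from 12000 nM to 60000 nM, and with a fair chance that the assay again reports only a limit.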

Compound 4, half-maximal effective concentration: > 25000 nM
Compound 4: a limit, no number (the forecaster's own chance of this, stated with the estimate: 60%); the middle value lies on the limit itself.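

In this assay compound 4 gives > 25000 nM, which is a limit and not a number. Among these compounds, compound 2 is also known only as a limit, and no step from compound 2 to compound 4 can be read: the limit of > 25000 nM in this assay, at which 3 of the 4 values shown sit. The compounds shown leave open whether fluoro in place of amino on an aromatic carbon changes the effective concentration at all.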